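Swapping an Aryl Group for a Styryl Arm

The source may report more compounds than this note shows. Statements on the series, on what has been measured and on what is new or still open speak of the compounds shown alone.

Two compounds in this small set carry numbers. In a functional assay on HCT-116 cells (Homo sapiens) for inhibition, read by sulforhodamine B assay, with a stated time of 48 h (on this read-out higher numbers stand for weaker inhibition and lower numbers for stronger inhibition), compound 1 `COc1ccc(C(c2ccc(OC(C)CN(C)C)cc2)c2cccc3ccccc23)c(OC)c1OC` gives 8410 nM. Compound 2 `COc1ccc(C(O)(Cc2ccc(C)cc2)c2cccc3ccccc23)c(OC)c1OC` reaches only a limit in this assay, > 20000 nM, which is the limit of > 20000 nM in this assay, at which 1 of the 2 values shown sits. Compound 3 `COc1ccc(C(O)(C/C=C\c2ccccc2)c2cccc3ccccc23)c(OC)c1OC` differs from compound 2 in a single place: 2-phenylethenyl in place of 4-methylphenyl on a saturated chain carbon, two bonds along the chain from two aromatic carbons and an oxygen on a saturated carbon. Within the data shown here, no measured step between related compounds exists here, so the expected change is none beyond the usual scatter in this assay, and compound 3 is expected to remain weak. Compound 3 is estimated at 20000 nM, within a range from 5000 nM to 60000 nM. That corresponds to an expected step of a number no higher from compound 2 to compound 3 (the limit leaves the size open).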

Compound 3, half-maximal inhibitory concentration: > 20000 nM
Compound 3 was reported as a limit; the forecaster's own chance of this, stated with the estimate: 60%; the middle value sits exactly at the limit.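

In this assay compound 2 and compound 3 both end at a limit, so no step can be read between them: the limit of > 20000 nM in this assay, at which 2 of the 3 values shown sit.

Going by these compounds, whether 2-phenylethenyl or 4-methylphenyl gives stronger inhibition stays open, as does how far past the limit either compound lies.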